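This account rests on a few compounds, and the source may have more. Where it says the series, first, only, none or still open, it means among the compounds named here.

Measured so far:
- compound 1 `O=C(N/N=C/c1ccc(-c2ccc(F)cc2F)o1)c1ccccc1O`: 63.4%
- compound 2 `O=C(N/N=C/c1ccc(O)cc1)c1ccc(-c2ccc(F)cc2)o1`: 10.6%
- compound 3 `COc1ccccc1C(=O)N/N=C/c1ccc(-c2ccc(F)cc2F)o1`: 1.69%

These three compounds were all tested in a functional assay on Bel-7402 cells (Homo sapiens) for inhibition, read by sulforhodamine B assay, with a stated time of 48 h, tested at 10 uM; a higher number here means more inhibition of growth at the concentration tested, a lower number less inhibition of growth. Compound 2 stands second of the three in this assay, with 10.6%; its number is within the scatter of the number for compound 3, and far below the number for compound 1, which is the only one of the three with clearly strong inhibition.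

The next compound, compound 4 `O=C(N/N=C/c1ccccc1Cl)c1ccc(-c2ccc(F)cc2)o1`, arises from compound 2 by one change: 2-chlorophenyl in place of 4-hydroxyphenyl on a carbon with a double bond to nitrogen

Going by the values given here, only one measured step is available, and it is of a different kind: a number 61.7 percentage points lower from compound 1 to compound 3 (beyond the scatter). That step shows that covering the hydrogen of a hydroxyl on an aromatic ring wiped out most of the inhibition. The change to compound 4 also removes a hydroxyl, but from a compound whose inhibition is already low, so there is little room for a further fall. No step beyond the scatter is therefore expected in this assay. Compound 4 is estimated at 10%, within -5% to 35%, which would mean an expected step of a number 0.6 percentage points lower from compound 2 to compound 4 (within the scatter).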

Compound 4, percent growth inhibition at one concentration: 4.81%
The estimate for compound 4 lay 5.2 percentage points above the measured number; measured number inside the range.
By their numbers in this assay, from the lowest: compounds 3, 4 and 2 (each within the scatter of the next); then compound 1.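

Placing 2-chlorophenyl in place of 4-hydroxyphenyl on the carbon with a double bond to nitrogen gives, in this assay, a number 5.8 percentage points lower from compound 2 to compound 4 (within the scatter). Going by these compounds alone, this is the first view of this place, and it shows that the hydrogen-bond donor and acceptor counted on the 4-hydroxyphenyl can be exchanged for a chlorine-bearing ring with no change beyond the scatter, although the inhibition of compound 2 was already low, so this step could show little loss. No measurement is available that explains this result.

From the compounds shown here alone, it remains open whether an aminophenyl or a carboxyphenyl group at this place would raise inhibition above this low level. Also open, going by these compounds, is how 2-chlorophenyl would behave on a compound with strong inhibition, such as compound 1, where a fall could be seen clearly.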